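The compounds below may be only part of what the source reports. "The series", "measured", "known", "first", "only" and "open" are said of these compounds alone.

Measured compounds:
- compound 1, `CCn1ccc2cc(C(O)c3ccc(OC)c(OC)c3OC)ccc21`: > 10000 nM
- compound 2, `COc1ccc(/C(=N\OC(C)=O)c2ccc3c(ccn3C)c2)c(OC)c1OC`: 580 nM

Of the compounds shown here, two have been tested in a functional assay on HL-60 cells (Homo sapiens) for cytotoxicity, read by XTT assay, with a stated time of 72 h; on this read-out higher numbers stand for weaker inhibition and lower numbers for stronger inhibition. Compound 1 gives only a limit, > 10000 nM, and the assay therefore reports no number for it. Among the measured compounds shown here, compound 2 gives 580 nM, and this is the only actual number in the set. The remaining entry sits at the limit of > 10000 nM in this assay, at which 1 of the 2 values shown sits, a limit rather than a measurement, so compound 2 cannot be ranked against anything else.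

Compound 3, `COc1ccc(/C(=N\NC(C)=O)c2ccc3c(ccn3C)c2)c(OC)c1OC`, has not yet been measured. It differs from compound 2 by acetamido in place of acetoxy on a double-bonded nitrogen, an acetamido in place of acetoxy on a double-bonded nitrogen. For the measured compounds named here, no pair of measured compounds differs in a single place, so no measured step indicates how such a change plays out here. The step from compound 2 to compound 3 is expected to be a 2.1-fold higher number from compound 2 to compound 3 (0.32 log units; beyond the scatter), a modest loss at most, possibly none beyond the scatter. Compound 3 is accordingly estimated at 1200 nM, within a range from 300 nM to 5000 nM.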

Compound 3, half-maximal inhibitory concentration: 2000 nM
Compound 3: the middle estimate sits 1.7-fold (0.22 log units) below what was measured, within the range that was stated.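

In this assay, among the compounds shown here, the swap of acetoxy for acetamido on a double-bonded nitrogen gives the first measured step at this position: a 3.4-fold higher number from compound 2 to compound 3 (0.54 log units; beyond the scatter), a modest loss that lies beyond the scatter. The position therefore accepts either group on the shared core, and compound 3 still gives a measured number, 2000 nM, rather than a limit. Nothing measured here accounts for the size of this step.

A single step cannot show whether the loss goes with the hydrogen-bond donor that acetamido carries or with some other difference between the two groups. Going by these compounds, how a longer acyl chain, a free hydroxyl or an amine on the same double-bonded nitrogen would read in this assay also remains open.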